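The compounds below may be only part of what the source reports. "The series", "measured", "known", "first", "only" and "open" are said of these compounds alone.

In a functional assay on cells (Platelet, Homo sapiens) for inhibition (a higher number here means a weaker inhibitor, a lower number a stronger inhibitor), compound 1 `CCOC(=O)c1ccc(-c2nn(C)c3ccccc23)cc1` gives > 10000 nM, which is a limit of the assay and not a number. Compound 2 `CCOC(=O)c1ccc(-c2nn(Cc3ccc(Cl)cc3)c3ccccc23)cc1` gives > 10000 nM, which is also a limit. The picture so far is therefore (the limit of > 10000 nM in this assay, at which 2 of the 2 values shown sit). Among the measured compounds shown here, the only measured step is a step that the two limits leave unreadable from compound 1 to compound 2, with 4-chlorophenyl in place of hydrogen on a saturated chain carbon bound to an aromatic nitrogen.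

Compound 3 `CCOC(=O)c1ccc(-c2nn(Cc3ccccc3F)c3ccccc23)cc1` differs from compound 2 in one place: 2-fluorophenyl in place of 4-chlorophenyl on a saturated chain carbon bound to an aromatic nitrogen. Here 2-fluorophenyl stands in place of 4-chlorophenyl, so the change can also be read as 4-chlorobenzyl to 2-fluorobenzyl. The measured step has no readable size, so it offers no size to carry over to this change. The expectation must stay broad, and a second result at the limit is about as likely as a readable number. If a number does appear, it is expected on the stronger side of the limit. The estimated change is an at least 2.0-fold lower number from compound 2 to compound 3 (0.30 log units; that floor lies within the scatter), and this is only a rough expectation. For compound 3 the expected value is 5000 nM, with an estimated range from 300 nM to 20000 nM.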

Compound 3, half-maximal inhibitory concentration: > 10000 nM
Compound 3 was reported as a limit; the forecaster's own chance of this, stated with the estimate: 50%; at least 2.0-fold (0.30 log units) between middle value and limit.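

Compound 1, compound 2 and compound 3 are all reported only as limits in this assay, so the steps among these compounds cannot be read: the limit of > 10000 nM in this assay, at which 3 of the 3 values shown sit.

The compounds shown leave open whether any group on the saturated chain carbon bound to an aromatic nitrogen can give a readable number in this assay.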